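A chlorophenyl swap on a piperidine amide chain

This account rests on a few compounds, and the source may have more. Where it says the series, first, only, none or still open, it means among the compounds named here.

Compound 1 `O=C(/C=C/CCCCCCc1ccccc1)N1CCCCC1` and compound 2 `O=C(CCCCCCCCCCc1ccccc1)N1CCCCC1` were tested in a functional assay on PANC-1 cells (Homo sapiens) for cytotoxicity, read by WST assay, with a stated time of 24 h; on this read-out lower numbers stand for stronger inhibition and higher numbers for weaker inhibition. Compound 1 gives > 100000 nM, which is a limit of this assay. Compound 2 gives > 100000 nM, also a limit of this assay. Among the measured compounds shown here, compound 2 therefore stands at the limit of > 100000 nM in this assay, at which 2 of the 2 values shown sit, and no measured step exists between the two. Compound 3 `O=C(CCCCCCCCc1ccc(Cl)cc1)N1CCCCC1` awaits measurement in this assay. It differs from compound 2 by 4-chlorophenyl in place of phenethyl on a saturated chain carbon, eight bonds along the chain from a carbonyl carbon. For the measured compounds named here, no measured step resembles this change, so no shift beyond the scatter is expected. The step expected is a number no higher from compound 2 to compound 3 (the limit leaves the size open). Compound 3 is estimated at 100000 nM, within 30000 nM to 300000 nM, most likely again reported as a limit.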

Compound 3, half-maximal inhibitory concentration: 65500 nM
Compound 3: middle estimate off by 1.5-fold (0.18 log units), on the high side; the range from low to high includes it.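

In this assay, among the compounds shown here, compound 3 gives 65500 nM, the first real number in this set rather than a limit, so 4-chlorophenyl in place of phenethyl at this place on the chain does yield a reading. The swap gives an at least 1.5-fold lower number from compound 2 to compound 3 (0.18 log units; that floor lies within the scatter), and a floor within the usual scatter does not establish a real gain. Its true size cannot be fixed because compound 2 offers only a limit: the limit of > 100000 nM in this assay, at which 2 of the 3 values shown sit.

Going by these compounds, whether the chlorine itself matters remains open. So does what a 4-methoxyphenyl or a 4-aminophenyl group would give at this place.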